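The source may hold more compounds than are shown below. What is called first, only, known or untested is meant among the compounds shown, and "the series" means these compounds.

Among the measured compounds shown here, in an ADME assay on Vero cells (Chlorocebus sabaeus) for inhibition (on this read-out higher numbers stand for lower toxicity in this test and lower numbers for higher toxicity in this test), compound 1 (`COc1ccc(/C=C2\CCC/C(=C\c3cccc(OC)c3OC)C2=O)cc1`) gives 401000 nM, the only exact number so far. For the measured compounds named here, the sole comparison is compound 2 (`COc1cccc(/C=C2\CCC/C(=C\c3ccc([N+](=O)[O-])cc3)C2=O)c1OC`). Compound 2 reads < 10000 nM, which is a limit of the assay. That leaves compound 1 at the less toxic end of what has been seen. Compound 3 (`COc1ccc(/C=C2\CCC/C(=C\c3cccc(OC)c3OC)C2=O)cc1OC`) is compound 1 with one change: methoxy in place of hydrogen on an aromatic carbon. Going by the values given here, the only measured step, an at least 40-fold lower number from compound 1 to compound 2 (1.60 log units; beyond the scatter), is large, but it puts a nitro in place of a methoxy, a different exchange, so it offers little guidance here. Compound 3 brings in no nitro, only a further methoxy, a group compound 1 already carries. A small step of a 1.3-fold lower number from compound 1 to compound 3 (0.10 log units; within the scatter) is therefore expected, within the scatter and with no firm direction. For compound 3 the estimated value in this assay is 320000 nM, with an expected range of 120000 nM to 800000 nM.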

Compound 3, half-maximal cytotoxic concentration: 36100 nM
The estimate for compound 3 lay 8.9-fold (0.95 log units) above the measured number; the whole stated range lies above it.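

In this assay, placing a methoxy in place of hydrogen on an aromatic carbon, ortho to a methoxy group and meta to a large group, gives an 11-fold lower number from compound 1 to compound 3 (1.05 log units; beyond the scatter). This position is therefore not indifferent to substitution: a group that compound 1 already carries elsewhere can still move the number by a large step, so a large step is not confined to the exchange for nitro. Compound 2 remains a limit and not a number, so the size of its step cannot be set against this one: the limit of < 10000 nM in this assay, at which 1 of the 3 values shown sits.

With only one group shown at this carbon, it stays open whether the step belongs to methoxy itself or would follow any group placed there. A hydroxyl, a fluorine or an amine at the same carbon would separate those two readings.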